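Diacid side chains at the assay limit

The source may hold more compounds than are shown below. What is called first, only, known or untested is meant among the compounds shown, and "the series" means these compounds.

In a functional assay on PC-3 cells (Homo sapiens) for antiproliferative activity, read by MTT assay, with a stated time of 24 h (on this read-out lower numbers stand for stronger inhibition and higher numbers for weaker inhibition), compound 1 `CCn1c(C(=O)N[C@@H](C)C(=O)OC)ccc1C(CC)(CC)c1ccc(OCS(=O)(=O)c2ccccc2)c(C)c1` gives > 50000 nM as a limit and not a number. Compound 2 `CCn1c(C(=O)N[C@@H](CC(=O)O)C(=O)O)ccc1C(CC)(CC)c1ccc(OCS(=O)(=O)c2ccccc2)c(C)c1` likewise stands at > 50000 nM as a limit. Among the compounds with values here, the only measured step is a step that the two limits leave unreadable from compound 1 to compound 2 and so offers no size to carry forward. Within the data shown here, the series so far shows the limit of > 50000 nM in this assay, at which 2 of the 2 values shown sit, and no number. Compound 3 `CCn1c(C(=O)N[C@H](CCC(=O)O)C(=O)O)ccc1C(CC)(CC)c1ccc(OCS(=O)(=O)c2ccccc2)c(C)c1` carries 1,3-dicarboxypropyl in place of 1,2-dicarboxyethyl on an amide-type nitrogen. The expected step in this assay is a number no higher from compound 2 to compound 3 (the limit leaves the size open) and no shift beyond the scatter is expected in either direction. For compound 3 the estimated value is 50000 nM (range 20000 nM to 100000 nM) and a further limit is likely.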

Compound 3, half-maximal inhibitory concentration: > 50000 nM
Compound 3 gave a limit, no number; the forecaster's own chance of this, stated with the estimate: 85%; the middle value lies on the limit itself.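

No step can be read among compound 1, compound 2 and compound 3, each of which gives a limit and not a number: the limit of > 50000 nM in this assay, at which 3 of the 3 values shown sit.

The compounds shown leave open whether any side chain on the shared core gives a number in this assay.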